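Methylating the indole nitrogen in a longer-chain analogue

This account rests on a few compounds, and the source may have more. Where it says the series, first, only, none or still open, it means among the compounds named here.

Three compounds in this set were tested in a functional assay on MCF7 cells (Homo sapiens) for cytotoxicity, read by MTT assay, with a stated time of 48 h; on this read-out higher numbers stand for weaker inhibition and lower numbers for stronger inhibition. Compound 1 `CCCCCCCCCCCCCCNC(=O)[C@@H](NC(=O)c1cc2ccccc2[nH]1)[C@@H](C)O` gives 15100 nM. Compound 2 `CCCCCCCCCCCCCCNC(=O)[C@@H](NC(=O)c1cc2ccccc2n1C)[C@@H](C)O` gives 25700 nM, and the difference between them is methyl in place of hydrogen on an aromatic nitrogen, a step of a 1.7-fold higher number from compound 1 to compound 2 (0.23 log units; within the scatter). Compound 3 `CCCCCCCCCCCCCCCCCCNC(=O)[C@@H](NC(=O)c1cc2ccccc2[nH]1)[C@@H](C)O` gives 35700 nM; here the difference from compound 1 lies in the chain, (butyl in place of hydrogen on a saturated chain carbon, ten or more bonds along the chain from an amide-type nitrogen), and the step is a 2.4-fold higher number from compound 1 to compound 3 (0.37 log units; beyond the scatter). Compound 4 `CCCCCCCCCCCCCCCCCCNC(=O)[C@@H](NC(=O)c1cc2ccccc2n1C)[C@@H](C)O` has not yet been measured. It differs from compound 3 by methyl in place of hydrogen on an aromatic nitrogen, which is the same change, at the same place, as that from compound 1 to compound 2. Within the data shown here, the only guide to its effect is that single earlier step, which fell within the scatter, so the expectation for compound 4 rests on a shift of about the same size applied to compound 3, with the caveat that one pair cannot show whether the change behaves alike on a longer chain. The expected step is a 1.5-fold higher number from compound 3 to compound 4 (0.19 log units; within the scatter). In this assay compound 4 is therefore estimated at 55000 nM, most likely between 30000 nM and 110000 nM.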

Compound 4, half-maximal inhibitory concentration: 36400 nM
For compound 4 the middle estimate is 1.5-fold (0.18 log units) above the measured one; the measured number falls inside the stated range.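

In this assay, methyl in place of hydrogen on the aromatic nitrogen gives a 1.0-fold higher number from compound 3 to compound 4 (0.01 log units; within the scatter), and set beside the earlier step on the shorter chain, the two agree: the same change on two cores in this assay, a 1.7-fold higher number (0.23 log units; within the scatter) from compound 1 to compound 2 and a 1.0-fold higher number (0.01 log units; within the scatter) from compound 3 to compound 4, 1.7-fold (0.22 log units) apart, within the scatter of two such steps. Among these compounds, the chain change, butyl in place of hydrogen on a saturated chain carbon, gives a 1.4-fold higher number from compound 2 to compound 4 (0.15 log units; within the scatter) on the methylated core, and it also agrees with its counterpart on the core bearing hydrogen on that nitrogen, even though only that earlier step lies beyond the scatter: the same change on two cores in this assay, a 2.4-fold higher number (0.37 log units; beyond the scatter) from compound 1 to compound 3 and a 1.4-fold higher number (0.15 log units; within the scatter) from compound 2 to compound 4, 1.7-fold (0.22 log units) apart, within the scatter of two such steps. So across these four compounds, neither change shows a detectable dependence on the core, but with only two steps per change, this does not prove that the effects are identical or that they would carry over to other cores.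

Going by these compounds, it remains open how a larger group on the aromatic nitrogen, such as ethyl or benzyl, would compare with methyl. The compounds shown also leave open how a shorter chain, such as decyl, or a longer chain would behave on either core.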